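From hydroxy to methoxymethyl on a side chain

This account rests on a few compounds, and the source may have more. Where it says the series, first, only, none or still open, it means among the compounds named here.

In a functional assay on HT-29 cells (Homo sapiens) for cytotoxicity, read by MTT assay, with a stated time of 48 h (a higher number here means a weaker inhibitor, a lower number a stronger inhibitor), compound 1 (`COc1cc(/C=C/C(=O)/C=C(/C=C/c2ccc(O)c(OC)c2)NCCO)ccc1O`) gives > 100000 nM, which is a limit of the assay and not a number. Compound 2 (`COCCNC(=C\C(=O)/C=C/c1ccc(O)cc1)/C=C/c1ccc(O)cc1`) gives a measured 57400 nM. Compound 3 (`COCCCNC(=C\C(=O)/C=C/c1ccc(O)c(OC)c1)/C=C/c1ccc(O)c(OC)c1`) differs from compound 1 by methoxymethyl in place of hydroxy on a saturated chain carbon, two bonds along the chain from an amine nitrogen, with methoxymethyl in place of hydroxy on a saturated chain carbon, two bonds along the chain from an amine nitrogen. Within the data shown here, no measured step guides this change, and compound 2 at 57400 nM is the only number available, so only a small gain in this assay is expected. The expected change is an at least 1.4-fold lower number from compound 1 to compound 3 (0.15 log units; that floor lies within the scatter). For compound 3, the estimate is 70000 nM, with an expected range from 30000 nM to 150000 nM.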

Compound 3, half-maximal inhibitory concentration: 72200 nM
Compound 3: the middle estimate sits 1.0-fold (0.01 log units) below what was measured; measured number inside the range.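

With the 3-methoxypropyl group in place of 2-hydroxyethyl on the amine, the core of compound 1 now gives a measured number in this assay, and the change reads as an at least 1.3-fold lower number from compound 1 to compound 3 (0.14 log units; that floor lies within the scatter). The value of compound 1 is a limit and not a number, so the true size of this step stays unknown, because the comparison starts from that limit: the limit of > 100000 nM in this assay, at which 1 of the 3 values shown sits.

The change lengthens the chain and replaces the hydroxy end in one move, and the compounds shown do not separate these two parts. A plain propyl chain, or a chain ending in an amine or a carboxylic acid, would help to tell them apart.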